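This account rests on a few compounds, and the source may have more. Where it says the series, first, only, none or still open, it means among the compounds named here.

Working notes on the series.

Compound 1 `COC(=O)C1=C(C)NC(C)=C(C(=O)OC)C1c1[nH]cnc1Cl` is the weaker of the two measured compounds: in an assay on isolated protein for inhibition of Voltage-dependent L-type calcium channel subunit alpha-1C (Cavia porcellus) (a higher number here means a weaker inhibitor, a lower number a stronger inhibitor), compound 1 gives 1200 nM, the highest number among the two values at hand. The other measured compound, compound 2 `CC1=C(C(=O)OCCc2ccccc2)C(c2nc[nH]c2Cl)C(C(=O)OCCc2ccccc2)=C(C)N1`, carries phenethyl esters on both sides of the shared core, and in this assay compound 2 gives 0.182 nM; the two values lie far apart, well beyond the scatter, with the larger esters on the side of the lower number.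

Compound 3 `COC(=O)C1=C(C)NC(C)=C(C(=O)OCC2CCCCC2)C1c1[nH]cnc1Cl` is the next step from compound 1: cyclohexyl in place of hydrogen on a saturated chain carbon bound to an oxygen next to a carbonyl group. One of the two methyl esters of compound 1 thus becomes a cyclohexylmethyl ester while the other methyl ester is kept.

Going by the values given here, no measured step of exactly this kind exists in the set, so the expectation rests on the contrast between compound 1 and compound 2 alone. Given that the pair with larger esters sits at a far lower number, the step from compound 1 to compound 3 is expected to lower the number by a large margin, a 60-fold lower number from compound 1 to compound 3 (1.78 log units; beyond the scatter), though with only one ester changed the drop is expected to stop short of the value of compound 2. Compound 3 is estimated at 20 nM in this assay, with a plausible range of 3 nM to 150 nM.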

Compound 3, half-maximal inhibitory concentration: 355 nM
Compound 3: the middle estimate sits 18-fold (1.25 log units) below what was measured; the whole stated range lies below it.
By their numbers in this assay, from the lowest: compound 2; then compound 3; then compound 1.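

Replacing hydrogen with cyclohexyl on a saturated chain carbon bound to an oxygen next to a carbonyl group gives in this assay a modest change, a 3.4-fold lower number from compound 1 to compound 3 (0.53 log units; beyond the scatter), which is beyond the scatter. Going by these compounds alone, this is the first reading of a change at a single ester: with the other methyl ester kept, the move from methyl to cyclohexylmethyl shifts the number only by this modest margin, whereas compound 2 differs from both compound 1 and compound 3 in more than one place and so cannot be set against this step. Nothing at hand explains the size of the step.

The compounds shown leave open how this ester position responds to groups other than cyclohexylmethyl, such as a benzyl ester, a phenethyl ester paired with a methyl ester, or a longer chain such as n-hexyl. They also leave open whether a tertiary amine at the end of the ester chain or a carboxylic acid in place of the ester would move the number further, and whether a change at the second ester adds to the one seen here.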